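The compounds below may be only part of what the source reports. "The series", "measured", "known", "first", "only" and "open" are said of these compounds alone.

Measured so far in an ADME assay on MT4 cells (Homo sapiens) for cytotoxicity, read by MTT assay; on this read-out higher numbers stand for lower toxicity in this test and lower numbers for higher toxicity in this test:
- compound 1 `O=c1cc(Cc2c(F)cccc2F)nc(SCCCc2ccccc2)[nH]1`: 32000 nM
- compound 2 `O=C(CSc1nc(Cc2c(F)cccc2F)cc(=O)[nH]1)c1ccccc1`: > 67000 nM

Compound 2 stands at the limit of > 67000 nM in this assay, at which 1 of the 2 values shown sits, so its place is marked by a limit of the assay and not by a number. Compound 3 `O=C(CSc1nc(Cc2c(F)cccc2F)cc(=O)[nH]1)c1ccc(Cl)cc1` differs from compound 2 by chloro in place of hydrogen on an aromatic carbon, which turns the phenyl into 4-chlorophenyl. Within the data shown here, only one measured step is available, an at least 2.0-fold higher number from compound 1 to compound 2 (0.32 log units; beyond the scatter). Among the measured compounds shown here, that step changes a different part of the side chain, and no measured step introduces a chloro, so it gives neither size nor direction for this change. No step beyond the scatter is therefore expected in this assay, and the estimated step reads an at least 1.3-fold lower number from compound 2 to compound 3 (0.12 log units; that floor lies within the scatter). For compound 3 the expected value is 50000 nM, with an estimated range of 18000 nM to 75000 nM.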

Compound 3, half-maximal cytotoxic concentration: > 61000 nM
Compound 3 gave a limit, no number; the forecaster's own chance of this, stated with the estimate: 60%; at least 1.2-fold (0.08 log units) between middle value and limit.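

With chloro on the phenyl, the benzoyl side chain still gives no measured number in this assay, and compound 3 gives only a limit of the assay: the limit of > 61000 nM in this assay, at which 1 of the 3 values shown sits. The comparison with the phenethyl side chain reads an at least 1.9-fold higher number from compound 1 to compound 3 (0.28 log units; that floor lies within the scatter), a floor that lies within the scatter, so this pair alone does not separate compound 3 from compound 1. The effect of the chloro itself cannot be read, since compound 2 also gives only a limit: the limit of > 67000 nM in this assay, at which 1 of the 3 values shown sits.

On these data alone, how far the true values of compound 2 and compound 3 lie from their limits stays open, and with it whether chloro changes the read-out at all. Also open, as far as these compounds go, is whether an amine or a carboxylic acid at the place of the chloro would give a measurable number in this assay.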